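The source may hold more compounds than are shown below. What is called first, only, known or untested is meant among the compounds shown, and "the series" means these compounds.

In a functional assay (mast cells) for inhibition, with Rattus norvegicus as the target (a lower number here means that less compound is needed, a higher number that more compound is needed for the effect), compound 1 (`CCOC(=O)c1cnc2n(c1=O)C(C)CC/C2=N\Nc1ccc(C(=O)O)cc1`) gives 66000 nM and compound 2 (`CC(=O)c1ccc(N/N=C2\CCC(C)n3c2ncc(C(=O)O)c3=O)cc1`) gives 8100 nM as the lower of the two numbers, a gap beyond the usual scatter. Compound 3 (`CC1CC/C(=N\Nc2ccc(C(=O)O)cc2)c2ncc(C(=O)O)c(=O)n21`) differs from compound 2 by hydroxy in place of methyl on a carbonyl carbon, acetyl to carboxy (hydroxy in place of methyl on a carbonyl carbon). For the measured compounds named here, no measured pair shows this change, so in this assay only a small rise in the number, within the scatter, is expected. The estimated change is a 1.5-fold higher number from compound 2 to compound 3 (0.17 log units; within the scatter) and remains uncertain. Compound 3 is expected at 12000 nM with an estimated range of 3000 nM to 50000 nM overall.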

Compound 3, half-maximal effective concentration: 1000000 nM
Estimate against measurement, compound 3: 83-fold (1.92 log units) below, outside the stated range (above it).
By their numbers in this assay, from the lowest: compound 2; then compound 1; then compound 3.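

In this assay the change from acetyl to carboxy is far from neutral at this place: hydroxy in place of methyl on a carbonyl carbon gives a 120-fold higher number from compound 2 to compound 3 (2.09 log units; beyond the scatter) and so raises the number sharply. Hydrogen in place of ethyl on an oxygen next to a carbonyl group gives a 15-fold higher number from compound 1 to compound 3 (1.18 log units; beyond the scatter) and so also raises it beyond the scatter. Nothing at hand explains either step. From the compounds shown here alone, whether an amide or a methyl ester in place of the carboxy of compound 3 would bring the number back down remains open.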